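Swapping one aromatic group on compound 3

The source may hold more compounds than are shown below. What is called first, only, known or untested is meant among the compounds shown, and "the series" means these compounds.

Compound 1 `COc1ccc(-c2cc(NNC(=O)Nc3cc(Cl)nc(Cl)c3)nc3c2cnn3C)cc1` gives 12300 nM here
Compound 2 `CCN(CC)c1cc(NC(=O)NNc2cc(-c3ccc(F)cc3)c3cnn(C)c3n2)cc(Cl)n1` gives 29400 nM here
Compound 3 `Cn1ncc2c(-c3ccc(F)cc3)cc(NNC(=O)Nc3cc(Cl)nc(OCCF)c3)nc21` gives 37200 nM here

All three numbers come from a functional assay on HCT-116 cells (Homo sapiens) for cytotoxicity, read by MTT assay, with a stated time of 48 h, in the presence of a further agent that is not named here (a higher number here means that more compound is needed for the effect, a lower number that less compound is needed), and form a small set. Compound 3 at 37200 nM and compound 2 at 29400 nM lie within the usual scatter of each other, and both numbers are clearly higher than that of compound 1.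

Compound 4 `Cn1ncc2c(-c3ccc(F)cc3)cc(NNC(=O)Nc3cc(F)cc(F)c3)nc21` differs from compound 3 in one place: 3,5-difluorophenyl in place of 2-chloro-6-(2-fluoroethoxy)pyridin-4-yl on an amide-type nitrogen. The nearest measured step is 2-fluoroethoxy in place of diethylamino on an aromatic carbon, which gave a 1.3-fold higher number from compound 2 to compound 3 (0.10 log units; within the scatter) and stayed within the scatter. That step is only a loose guide, since it leaves the rest of the aromatic group in place. Compound 1 differs from compound 3 in more than one place, so its value cannot be tied to a single change.

No step beyond the scatter is therefore expected in this assay and any drift should be slight, towards lower numbers. The expected change is a 1.5-fold lower number from compound 3 to compound 4 (0.17 log units; within the scatter) (an estimate only). For compound 4 the estimated value is 25000 nM with an expected range from 9000 nM to 60000 nM at the two ends.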

Compound 4, half-maximal effective concentration: 46200 nM
For compound 4 the middle estimate is 1.8-fold (0.27 log units) below the measured one; the measured number falls inside the stated range.
By their numbers in this assay, from the lowest: compound 1; then compounds 2, 3 and 4 (each within the scatter of the next).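

This step changes far more than the earlier one, which altered a single substituent and left the rest of the aromatic group in place. Here the whole group on the amide-type nitrogen is exchanged: the ring nitrogen, the chlorine and the 2-fluoroethoxy chain all leave together, and a ring of carbon only, carrying two fluorines, enters. Even so, this assay shows a 1.2-fold higher number from compound 3 to compound 4 (0.09 log units; within the scatter), so for this pair the assay does not separate 2-chloro-6-(2-fluoroethoxy)pyridin-4-yl from 3,5-difluorophenyl, although the first has 2 hydrogen-bond acceptors and the second has 0. No measurement is available that would explain this outcome.

From the compounds shown here alone, it remains open what sets compound 1, at 12300 nM, apart from the others, as it differs from each of them in more than one place, so its value cannot be tied to one group. Also open, going by these compounds, is whether a non-aromatic group such as cyclohexyl, or a phenyl ring carrying a carboxylic acid, on this same nitrogen would produce a step beyond the scatter.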